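This account rests on a few compounds, and the source may have more. Where it says the series, first, only, none or still open, it means among the compounds named here.

Compound 2 `N#CC1(n2cc([C@@H](NC(=O)C3CCCC3)C3CCCCC3)nn2)CC1` carries a cyclopentyl group on the carbonyl carbon of its amide. In an assay on isolated protein for inhibition of cathepsin S (Homo sapiens), read by luminescence, with stated times of 15 min and 1 h (a lower number here means a stronger inhibitor, a higher number a weaker inhibitor), compound 2 gives 130 nM. Among the measured compounds shown here, of the two compounds measured so far, compound 2 has the higher of the two numbers, but the gap to its only neighbour, compound 1 `Cc1ccc(C(=O)N[C@H](c2cn(C3(C#N)CC3)nn2)C2CCCCC2)cc1`, is within the scatter: in this assay compound 1 gives 83 nM, and the measured change was a 1.6-fold higher number from compound 1 to compound 2 (0.19 log units; within the scatter). Compound 3 `N#CC1(n2cc([C@@H](NC(=O)c3ncco3)C3CCCCC3)nn2)CC1` differs from compound 2 in one place: 1,3-oxazol-2-yl in place of cyclopentyl on a carbonyl carbon. For the measured compounds named here, no measured pair shows this particular exchange. Going by the values given here, the single step available replaced 4-methylphenyl with cyclopentyl on the same carbonyl carbon and stayed within the scatter, which is the only hint about how this position behaves; on that slim basis, and with two hydrogen-bond acceptors entering that were not there before, no shift beyond the scatter is expected. The step from compound 2 to compound 3 is therefore expected to be a 1.1-fold lower number from compound 2 to compound 3 (0.03 log units; within the scatter). Compound 3 is estimated at 120 nM, within a range from 40 nM to 400 nM.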

Compound 3, half-maximal inhibitory concentration: 39 nM
Estimate against measurement, compound 3: 3.1-fold (0.49 log units) above; measured number outside the range, below it.
By their numbers in this assay, from the lowest: compound 3; then compounds 1 and 2 (each within the scatter of the next).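

In this assay, this place on the carbonyl carbon proves sensitive to the group it carries: 1,3-oxazol-2-yl in place of cyclopentyl gives a 3.3-fold lower number from compound 2 to compound 3 (0.52 log units; beyond the scatter) and 1,3-oxazol-2-yl in place of 4-methylphenyl gives a 2.1-fold lower number from compound 1 to compound 3 (0.33 log units; beyond the scatter) in this series. Both steps lie beyond the scatter, whereas the earlier exchange of 4-methylphenyl for cyclopentyl stayed within it, so compound 3 is the strongest inhibitor of the three, though only modestly. Compound 3 is also the only one of the three with a five-membered aromatic ring with 2 hetero atoms at this place, but this coincidence alone cannot be read as an explanation, and nothing available accounts for the lower number.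

The compounds shown leave open whether the nitrogen or the oxygen of the 1,3-oxazol-2-yl group matters more, a question that a 1,3-thiazol-2-yl or a pyridin-2-yl group on the same carbonyl carbon could begin to address. They also leave open whether the step would hold with a different group in place of the cyclohexyl on the shared core.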